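This account rests on a few compounds, and the source may have more. Where it says the series, first, only, none or still open, it means among the compounds named here.

Measured compounds:
Compound 1 `CS(=O)(=O)c1ccccc1Nc1nc2c(Nc3ccc(C(F)(F)F)cc3)ncnc2s1` gives 221 nM in a functional assay on HEK293 cells for antagonist activity at transient receptor potential cation channel subfamily V member 1 (Rattus norvegicus), read by calcium flux; a higher number here means a weaker inhibitor, a lower number a stronger inhibitor.
Compound 2 `Cc1nc(Nc2ccc(C(F)(F)F)c(Cl)c2)c2nc(Nc3c(Cl)cccc3Cl)sc2n1` gives 2 nM in this assay.

Among the measured compounds shown here, compound 2 stands lowest of the two numbers measured so far; its nearest neighbour is compound 1, which gives a number higher by a gap that lies well beyond the scatter of repeated measurements. The two compounds differ in several places at once, so no single change can be credited for the gap; the numbers alone show that compound 2 is the more potent inhibitor of the pair.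

Compound 3 `FC(F)(F)c1ccc(Nc2nc(-c3ccccc3)nc3sc(Nc4c(Cl)cccc4Cl)nc23)cc1Cl` has not yet been measured. It is reached from compound 2 by one change: phenyl in place of methyl on an aromatic carbon. For the measured compounds named here, no measured pair in this set shows the effect of such a change, so there is no step to lean on. The expectation here is for a small step in this assay, if any, possibly toward a slightly higher number but likely within the scatter; that is, the step of a 2.5-fold higher number from compound 2 to compound 3 (0.40 log units; beyond the scatter) is expected to be modest. Compound 3 is therefore estimated at 5 nM, with a range from 1.5 nM to 40 nM.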

Compound 3, half-maximal inhibitory concentration: 104 nM
Compound 3: middle estimate off by 21-fold (1.32 log units), on the low side, and the stated range ends below it.
By their numbers in this assay, from the lowest: compound 2; then compound 3; then compound 1.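

This position, on an aromatic carbon between two ring nitrogen atoms, proves far from indifferent to what it carries in this assay: phenyl in place of methyl gives a 52-fold higher number from compound 2 to compound 3 (1.72 log units; beyond the scatter), a large step well beyond the scatter. Among the compounds shown here, until this pair, no two measured compounds differed in one place, so nothing could be read about this position alone; now a single change there, with six carbon atoms and an aromatic ring entering for the one carbon of methyl, is seen to cost much of the potency, although the change adds no hydrogen-bond donors or acceptors and no net charge. Nothing measured here bears on why the step is so large.

With only methyl and phenyl at this position, the compounds shown leave open whether the loss comes with any group larger than methyl or with an aromatic ring in particular, a question that an ethyl chain, a cyclopropyl ring or a dimethylamino group could help to settle. Also open, going by these compounds, is whether the same change would give a step of similar size with different groups elsewhere on the shared core.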